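Shortening the Chain of Compound 2

The source may report more compounds than this note shows. Statements on the series, on what has been measured and on what is new or still open speak of the compounds shown alone.

Within the data shown here, in a functional assay on ASPC1 cells (Homo sapiens) for cytotoxicity (on this read-out lower numbers stand for stronger inhibition and higher numbers for weaker inhibition), compound 2 `Cc1ccc2nc(NC(=O)CCCCCCC(=O)NO)sc2c1` gives 0.54 ug/mL, the only actual number so far. Compound 1 `CS(=O)(=O)c1ccc2nc(NC(=O)CCCCC(=O)NO)sc2c1` is reported only as a limit of the assay, > 30 ug/mL. Compound 3 `Cc1ccc2nc(NC(=O)CCCCC(=O)NO)sc2c1` has not yet been measured. Its change from compound 2 is hydroxycarbamoyl in place of 2-(hydroxycarbamoyl)ethyl on a saturated chain carbon, four bonds along the chain from a carbonyl carbon. Among the measured compounds shown here, no measured pair shows what this change does in this assay, so the expectation is uncertain. A weakening beyond the usual scatter is expected, and compound 2 at 0.54 ug/mL leaves wide room for it. The estimated change is a 9.3-fold higher number from compound 2 to compound 3 (0.97 log units; beyond the scatter). For compound 3 the expected value is 5 ug/mL, with an estimated range of 1 ug/mL to 30 ug/mL.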

Compound 3, half-maximal inhibitory concentration: 13.3 ug/mL
The estimate for compound 3 lay 2.7-fold (0.42 log units) below the measured number, and the stated range covers the measured number.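

In this assay, the change from 2-(hydroxycarbamoyl)ethyl to hydroxycarbamoyl at this chain carbon gives a 25-fold higher number from compound 2 to compound 3 (1.39 log units; beyond the scatter), the first measured sign that chain length at this place strongly affects this read-out. With that shorter chain held constant, methyl in place of methylsulfonyl on an aromatic carbon gives an at least 2.2-fold lower number from compound 1 to compound 3 (0.35 log units; beyond the scatter), so the aromatic substituent also affects the read-out. Compound 1 is reported only as a limit, which makes the size of that step a lower bound: the limit of > 30 ug/mL in this assay, at which 1 of the 3 values shown sits.

The compounds shown leave open how a chain longer than that of compound 2 would read, and whether methylsulfonyl would have a similar effect on the longer chain. They also do not show how a carboxylic acid in place of the hydroxycarbamoyl end would read.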